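This account rests on a few compounds, and the source may have more. Where it says the series, first, only, none or still open, it means among the compounds named here.

Measured in a functional assay on HCT-15 cells (Homo sapiens) for cytotoxicity, read by sulforhodamine B assay, with a stated time of 48 h, tested at 1 uM; on this read-out higher numbers stand for a weaker effect at the one concentration tested and lower numbers for a stronger effect:
- compound 1 `COc1ccc(-c2cc(/C=C/C(=O)c3ccc(N)cc3)[nH]n2)cc1`: 50%
- compound 2 `COc1cc(-c2cc(/C=C/C(=O)c3ccc(N)cc3)[nH]n2)cc(OC)c1OC`: 60%
- compound 3 `COc1cc(-c2cc(/C=C/C(=O)c3ccc(Cl)c(Cl)c3)[nH]n2)cc(OC)c1OC`: 86%

Compound 2 holds the second highest of the three numbers. Its nearest neighbour is compound 1, whose value is within the scatter of that of compound 2; the furthest is compound 3, whose value lies beyond the scatter.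

Compound 4 `COc1ccc(-c2cc(/C=C/C(=O)c3ccc(N)cc3)[nH]n2)cc1OC` differs from compound 2 in one place: hydrogen in place of methoxy on an aromatic carbon.

Within the data shown here, the only measured step, a number 26 percentage points higher from compound 2 to compound 3 (beyond the scatter), changes the group on the carbonyl carbon and leaves the methoxy pattern untouched, so it does not bear on the change from compound 2 to compound 4. Among the measured compounds shown here, compound 1 and compound 2 carry different numbers of methoxy groups on the same ring, and their values sit within the scatter of each other; no single-point step joins them. On this basis the removal of one methoxy group is expected to give no step beyond the scatter, a number 4 percentage points lower from compound 2 to compound 4 (within the scatter). For compound 4 the estimate in this assay is 56%, with a range from 42% to 70%.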

Compound 4, a percentage reported as activity, at one concentration (the size of the read-out at that concentration, not a potency): 73%
Compound 4: the middle estimate sits 17 percentage points below what was measured, outside the stated range (above it).
By their numbers in this assay, from the lowest: compounds 1 and 2 (each within the scatter of the next); then compound 4; then compound 3.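

In this assay, hydrogen in place of methoxy on the aromatic carbon ortho to a methoxy group is not a silent change: it gives a number 13 percentage points higher from compound 2 to compound 4 (beyond the scatter) and so weakens the effect at the one concentration tested. Methoxy in place of hydrogen on compound 1 moves the same way, with a number 23 percentage points higher from compound 1 to compound 4 (beyond the scatter), so compound 4 stands above both of its one-place neighbours, and adding a methoxy group does not shift the read-out in one fixed direction: the step from compound 1 raises it, while the step that would take compound 4 to compound 2 lowers it. Nothing available explains this turn in the methoxy series.

Going by these compounds, whether compound 4's position above its neighbours holds with 3,4-dichlorophenyl on the carbonyl carbon remains open. So does the outcome with a hydroxyl, an ethoxy or a fluorine on this aromatic carbon, and whether the effect would be stronger or weaker at any concentration other than the one tested.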